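Fluoro to Nitro Swap and HeLa Growth Inhibition

The compounds below may be only part of what the source reports. "The series", "measured", "known", "first", "only" and "open" are said of these compounds alone.

Compound 1 `CC(=O)OC/C(=C\c1ccc(F)cc1)C(=O)c1ccccc1` gives 25000 nM in a functional assay on HeLa cells (Homo sapiens) for inhibition, read by sulforhodamine B assay, with a stated time of 48 h; on this read-out lower numbers stand for stronger inhibition of growth and higher numbers for weaker inhibition of growth.
Compound 2 `CC(=O)OC/C(=C\c1ccccc1F)C(=O)c1ccccc1` gives 22000 nM in this assay.
Compound 3 `CC(=O)OC/C(=C\c1ccc([N+](=O)[O-])cc1)C(=O)c1ccccc1` gives 26000 nM in this assay.

All three numbers lie close together. Compound 2 differs from compound 1 in one place, (2-fluorophenyl in place of 4-fluorophenyl on a double-bonded chain carbon bound to a double-bonded chain carbon), and the step is a 1.1-fold lower number from compound 1 to compound 2 (0.06 log units; within the scatter). Compound 3 differs from compound 1 by nitro in place of fluoro on an aromatic carbon; that step is a 1.0-fold higher number from compound 1 to compound 3 (0.02 log units; within the scatter).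

Compound 4 `CC(=O)OC/C(=C\c1ccccc1[N+](=O)[O-])C(=O)c1ccccc1` has not yet been measured. It differs from compound 2 by nitro in place of fluoro on an aromatic carbon. This is the same kind of change as between compound 1 and compound 3, but not the same: there the group sits para to a large group, here ortho to a large group. Because the earlier step of a 1.0-fold higher number from compound 1 to compound 3 (0.02 log units; within the scatter) stayed within the scatter, for compound 4 the step is expected to be a 1.0-fold higher number from compound 2 to compound 4 (0.02 log units; within the scatter). Compound 4 is estimated at 23000 nM, with the expected range from 12000 nM to 45000 nM.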

Compound 4, concentration for 50% growth inhibition: 25000 nM
For compound 4 the middle estimate is 1.1-fold (0.04 log units) below the measured one; the measured number falls inside the stated range.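

Nitro in place of fluoro, ortho to a large group, gives a 1.1-fold higher number from compound 2 to compound 4 (0.06 log units; within the scatter). Set beside the same swap on the core of compound 1, the two steps agree in this assay: the same change on two cores in this assay, a 1.0-fold higher number (0.02 log units; within the scatter) from compound 1 to compound 3 and a 1.1-fold higher number (0.06 log units; within the scatter) from compound 2 to compound 4, 1.1-fold (0.04 log units) apart, within the scatter of two such steps. So on these two cores the swap leaves the number where it was, but that is all this shows: it does not show that the swap would behave the same way on another core, and steps this small give no hint of why the numbers stay put.

The compounds shown leave open whether an amine or a carboxylic acid in place of the fluoro or nitro would move the number. They also leave open what a longer chain in place of the acetyl group would do.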